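The compounds below may be only part of what the source reports. "The series", "measured", "known", "first", "only" and "open" are said of these compounds alone.

Compound 1, `Cc1ccsc1CN[C@@H]1C[C@H]2C[C@@H]([C@H]1C)C2(C)C`, gives 10000 nM in an ADME assay on MDCK cells (Canis lupus familiaris) for cytotoxicity, read by microscopy, with a stated time of 48 h; a higher number here means that more compound is tolerated, a lower number that less compound is tolerated.
Compound 2, `C[C@H]1[C@H](NCc2cncnc2)C[C@H]2C[C@@H]1C2(C)C`, reaches only the limit of this assay, > 100000 nM, and so has no number.
Compound 3, `C[C@H]1[C@H](NCc2ccsc2)C[C@H]2C[C@@H]1C2(C)C`, gives 50000 nM in this assay.

Of the two compounds with a number, compound 3 stands highest, so more of it is tolerated than of compound 1: the step is a 5.0-fold higher number from compound 1 to compound 3 (0.70 log units; beyond the scatter). Against compound 2 the comparison is an at least 2.0-fold lower number from compound 2 to compound 3 (0.30 log units; that floor lies within the scatter). One of the three values is a limit: the limit of > 100000 nM in this assay, at which 1 of the 3 values shown sits.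

Compound 4, `C[C@H]1[C@H](NCc2ccc(Cl)s2)C[C@H]2C[C@@H]1C2(C)C`, has not yet been measured in this assay. It differs from compound 3 in one place: 5-chlorothiophen-2-yl in place of thiophen-3-yl on a saturated chain carbon bound to an amine nitrogen. For the measured compounds named here, no measured step swaps a thiophen-3-yl for a 5-chlorothiophen-2-yl, so the nearest guide is compound 1, whose 3-methylthiophen-2-yl on the same saturated chain carbon bound to an amine nitrogen tolerates less compound than compound 3 does, by a 5.0-fold higher number from compound 1 to compound 3 (0.70 log units; beyond the scatter). Compound 4 carries a substituted thiophen-2-yl as compound 1 does, so a step downward from compound 3, toward compound 1, is expected, of roughly a 2.5-fold lower number from compound 3 to compound 4 (0.40 log units; beyond the scatter). Compound 4 is therefore estimated at 20000 nM, with a likely range from 5000 nM to 100000 nM.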

Compound 4, minimum cytotoxic concentration: 25000 nM
Beside the measured number, compound 4's estimate is 1.3-fold (0.10 log units) below it; measured number inside the range.
By their numbers in this assay, from the lowest: compound 1; then compounds 4 and 3 (each within the scatter of the next). At a limit, above all of these: compound 2.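

In this assay, 5-chlorothiophen-2-yl in place of thiophen-3-yl on a saturated chain carbon bound to an amine nitrogen gives a 2.0-fold lower number from compound 3 to compound 4 (0.30 log units; within the scatter), so this change of thiophen group leaves no clear difference, whereas the two substituted thiophen-2-yl groups do separate, with a 2.5-fold higher number from compound 1 to compound 4 (0.40 log units; beyond the scatter). The pyrimidin-5-yl group, the only one here that is not a thiophen, stays clearly apart from the chlorinated group, with an at least 4.0-fold lower number from compound 2 to compound 4 (0.60 log units; beyond the scatter). Compound 2 gives a limit and not a number, so that step is only a floor: the limit of > 100000 nM in this assay, at which 1 of the 4 values shown sits.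

Going by these compounds, compounds 1 and 4 differ both in the substituent on the thiophen-2-yl ring and in where it sits, so the separate contributions of chlorine, methyl and their placement remain open. A plain thiophen-2-yl group on the same carbon would give the missing reference point, and a 3-chlorothiophen-2-yl group would compare chlorine with methyl at one ring position.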